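The source may hold more compounds than are shown below. What is called first, only, known or untested is meant among the compounds shown, and "the series" means these compounds.

Of the compounds shown here, three sharing one core have been measured in a functional assay on MCF7 cells (Homo sapiens) for antiproliferative activity, read by MTT assay, with a stated time of 72 h; a higher number here means a weaker inhibitor, a lower number a stronger inhibitor. Compound 1 `O=S1(=O)C=Cc2ccc(Nc3cccc(C(F)(F)F)c3)cc21`, carrying a trifluoromethyl group, gives 2500 nM in this assay. Compound 3 `COc1ccc(Nc2ccc3c(c2)S(=O)(=O)C=C3)cc1`, carrying a methoxy group, gives 1210 nM. Compound 2 `N#Cc1cccc(Nc2ccc3c(c2)S(=O)(=O)C=C3)c1`, carrying a cyano group, reaches only the limit of the assay, > 10000 nM. Compound 2 thus stands at the upper edge of what this assay reports, as noted by the limit of > 10000 nM in this assay, at which 1 of the 3 values shown sits. Within the data shown here, the one measured step that reaches compound 2 is an at least 4.0-fold higher number from compound 1 to compound 2 (0.60 log units; beyond the scatter), where cyano in place of trifluoromethyl raised the number beyond the scatter.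

Compound 4 `O=S1(=O)C=Cc2ccc(Nc3cccc(OC(F)(F)F)c3)cc21` differs from compound 2 in one place: trifluoromethoxy in place of cyano on an aromatic carbon. Trifluoromethoxy shares its three fluorines with the trifluoromethyl of compound 1 and its oxygen with the methoxy of compound 3, and those two compounds gave numbers close to each other. The change is therefore expected to undo the loss seen in going to cyano, and the expected step is an at least 5.0-fold lower number from compound 2 to compound 4 (0.69 log units; beyond the scatter). Compound 4 is estimated at 2000 nM, with a range from 800 nM to 5000 nM.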

Compound 4, half-maximal inhibitory concentration: 2020 nM
Beside the measured number, compound 4's estimate is 1.0-fold (0.00 log units) below it; the range from low to high includes it.
By their numbers in this assay, from the lowest: compounds 3, 4 and 1 (each within the scatter of the next, the first and the last beyond it). At a limit, above all of these: compound 2.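

In this assay, among these compounds, trifluoromethoxy at this aromatic carbon reverses the loss seen with cyano, with an at least 4.9-fold lower number from compound 2 to compound 4 (0.69 log units; beyond the scatter), so trifluoromethyl is not the only fluorinated group that this position accepts. The exchange of trifluoromethyl for trifluoromethoxy is not resolved by this assay, with a 1.2-fold lower number from compound 1 to compound 4 (0.09 log units; within the scatter), so the added oxygen and the larger group leave the reading within the scatter. The step from the cyano compound gives only a lower bound on the size of the change, because compound 2 stands at a limit of the assay and not at a number: the limit of > 10000 nM in this assay, at which 1 of the 4 values shown sits.

Cyano is the only group shown here that falls to the limit, so one case cannot show whether a wider rule lies behind it. From the compounds shown here alone, how an amine, a carboxylic acid or a longer alkyl chain would read at this aromatic carbon remains open.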